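Lengthening the diamine arm of a long-chain diamine

The source may hold more compounds than are shown below. What is called first, only, known or untested is meant among the compounds shown, and "the series" means these compounds.

Of the compounds shown here, three have been measured in a physicochemical assay for lipophilicity; on this read-out higher numbers stand for higher lipophilicity and lower numbers for lower lipophilicity. Compound 1, `CCCCCCCCCCCCNCCCN`, gives 5.06. Compound 2, `CCCCCCCCCCNCCCN`, gives 2.82. Compound 3, `CCCCCCCCCCCCCCNCCN`, gives 4.5, which places it second highest of the three: compound 1 stands above it by the step of a number 0.56 log units lower from compound 1 to compound 3 (beyond the scatter), and compound 2 stands well below it on the two values alone.

Compound 4, `CCCCCCCCCCCCCCNCCCN`, has not yet been measured. It differs from compound 3 by aminomethyl in place of amino on a saturated chain carbon, two bonds along the chain from an amine nitrogen, so the diamine arm grows by one carbon while the long hydrocarbon chain stays the same. For the measured compounds named here, two measured steps bear on this. The step of a number 2.24 log units lower from compound 1 to compound 2 (beyond the scatter) shows that taking away carbon from the chain lowers the read-out strongly. The step of a number 0.56 log units lower from compound 1 to compound 3 (beyond the scatter) shows that reshaping the diamine arm together with the chain moved the read-out only modestly. Adding a carbon is therefore expected to raise the number beyond the scatter, by roughly the step of a number 1.00 log units higher from compound 3 to compound 4 (beyond the scatter). Compound 4 is estimated at 5.5, with a likely range from 4.8 to 6.3.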

Compound 4, partition coefficient: 4.88
Beside the measured number, compound 4's estimate is 0.62 log units above it; low and high end bracket the measured number.
By their numbers in this assay, from the lowest: compound 2; then compound 3; then compounds 4 and 1 (each within the scatter of the next).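

In this assay, for the compounds shown here, aminomethyl in place of amino on a saturated chain carbon, two bonds along the chain from an amine nitrogen, is the first step that alters the diamine arm while the long hydrocarbon chain stays the same, and it gives only a modest change: a number 0.38 log units higher from compound 3 to compound 4 (beyond the scatter). Compound 4 also shows what happens when the arm stays fixed and only the chain changes, since butyl in place of hydrogen gives a number 2.06 log units higher from compound 2 to compound 4 (beyond the scatter), whereas ethyl in place of hydrogen gives a number 0.18 log units lower from compound 1 to compound 4 (within the scatter), so among these three compounds the large gain is seen only in the step that starts from compound 2, and compounds 1 and 4 cannot be told apart. No measurement shown here says why these steps differ in size.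

Still open, as far as these compounds go, is whether a longer chain than that of compound 4 would give a number that can be told apart from it. Open too, from the compounds shown here alone, is how a 4-aminobutyl arm, or a hydroxyl group in place of the terminal amine, would read on this scale.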